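The source may report more compounds than this note shows. Statements on the series, on what has been measured and on what is new or still open speak of the compounds shown alone.

Compound 1 `C/N=C(/S)C1=CC(C)(C)Oc2ccc([N+](=O)[O-])cc21` is the starting point of this small series. In a functional assay on the whole organism (aorta) with Rattus norvegicus as the target (on this read-out higher numbers stand for larger maximal responses and lower numbers for smaller maximal responses), compound 1 gives 63.5%. Compound 2 `C/N=C(/S)C1=CC(C)(C(F)(F)F)Oc2ccc([N+](=O)[O-])cc21` differs from compound 1 in one place: trifluoromethyl in place of methyl on a saturated ring carbon. In this assay compound 2 gives 62.5%, so that a number 1 percentage points lower from compound 1 to compound 2 (within the scatter). Compound 3 `CC1(C(F)(F)F)C=C(C(=O)NCCC#N)c2cc([N+](=O)[O-])ccc2O1` keeps the trifluoromethyl of compound 2 but carries another group on the double-bonded ring carbon; here a number 8.1 percentage points higher from compound 2 to compound 3 (within the scatter). In this assay compound 3 gives 70.6%. The difference between the core of compound 1 and the core of compound 3 is not broken down here.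

Compound 4 `N#CCCNC(=O)C1=CC(C(F)(F)F)(C(F)(F)F)Oc2ccc([N+](=O)[O-])cc21` has not yet been measured. It differs from compound 3 in one place: trifluoromethyl in place of methyl on a saturated ring carbon. Among the compounds with values here, this is the same kind of change as the one from compound 1 to compound 2, but the surroundings of the place differ: in compound 3 the ring atom two ring bonds away bears a (2-cyanoethyl)carbamoyl group (7 heavy atoms), whereas in compound 1 that ring atom bears a group of 4 heavy atoms. The change occurs twice among these compounds, and its one measured instance stayed within the scatter. For compound 4 the step is expected to be similar, a number 1.6 percentage points lower from compound 3 to compound 4 (within the scatter), because a number 1 percentage points lower from compound 1 to compound 2 (within the scatter). Compound 4 is therefore estimated to give 69% in this assay, with an expected range from 58% to 80%.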

Compound 4, intrinsic activity: the largest response reached, in percent of the reference agonist's: 64.1%
Estimate against measurement, compound 4: 4.9 percentage points above, and the stated range covers the measured number.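

Replacing methyl with trifluoromethyl on the saturated ring carbon next to the ring oxygen gives, in this assay, a number 6.5 percentage points lower from compound 3 to compound 4 (within the scatter). Set beside the same replacement on the other core, this step does not stand apart from the first one: the same change on two cores in this assay, a number 1 percentage points lower (within the scatter) from compound 1 to compound 2 and a number 6.5 percentage points lower (within the scatter) from compound 3 to compound 4, 5.5 percentage points apart, within the scatter of two such steps. So, across these two pairs, the replacement carries from one core to the other without a step beyond the scatter, but this does not prove that it has no effect or that the two cores respond identically, since a small real difference could be hidden within the scatter and each core offers only one pair.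

The compounds shown leave open whether the same holds when an amine or a carboxylic acid takes the place of the (2-cyanoethyl)carbamoyl group, or when that group carries a longer chain. They also leave open what an ethyl group would do on the saturated ring carbon, and whether this replacement would behave the same way on a read-out other than the maximal response.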